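Bromo for chloro at the limit of detection

A few compounds are considered here, and "the series" means these few. Any claim that something is new, unique, unknown or untested is made for them only; others in the source may bear on it.

In a functional assay on P388 cells (Mus musculus) for inhibition (on this read-out higher numbers stand for weaker inhibition and lower numbers for stronger inhibition), compound 2 `O=C1/C(=C/c2ccc(Cl)cc2)Cc2ccccc21` gives > 50000 nM, a limit and not a number. Compound 1 `O=C1/C(=C/c2ccc(F)cc2)Cc2ccccc21` gives > 50000 nM, also a limit. Compound 2 thus sits at the limit of > 50000 nM in this assay, at which 2 of the 3 values shown sit. Compound 4 `O=C1/C(=C/c2ccc(Br)cc2)Cc2ccccc21` differs from compound 2 by bromo in place of chloro on an aromatic carbon, para to a large group. Within the data shown here, the only measured step of this kind is a step that the two limits leave unreadable from compound 1 to compound 2, so it offers no size to carry over. Compound 3 `O=C1/C(=C/c2cccc(Br)c2)Cc2ccccc21`, with bromo at a different ring carbon, gives 21000 nM, so a small gain in inhibition or none beyond the scatter is expected in this assay. The expected change is an at least 1.2-fold lower number from compound 2 to compound 4 (0.09 log units; that floor lies within the scatter). Compound 4 is estimated at 40000 nM, with an expected range of 16000 nM to 90000 nM.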

Compound 4, half-maximal inhibitory concentration: > 50000 nM
Compound 4 gave a limit, no number (the forecaster's own chance of this, stated with the estimate: 45%); at least 1.2-fold (0.09 log units) between middle value and limit.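

Compound 1, compound 2 and compound 4 each give only a limit in this assay, so no step among them can be read: the limit of > 50000 nM in this assay, at which 3 of the 4 values shown sit.

The compounds shown leave open whether fluoro, chloro and bromo at this ring carbon differ in inhibition at all, and by how much.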